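The compounds below may be only part of what the source reports. "The series", "measured", "known", "first", "only" and "open" are said of these compounds alone.

Within the data shown here, in a functional assay on RS4-11 cells (Homo sapiens) for inhibition, read by CCK-8 assay, with a stated time of 48 h (a higher number here means a weaker inhibitor, a lower number a stronger inhibitor), compound 1 `COc1ccc(S(=O)(=O)Oc2ccccc2/C=C(\C#N)C(=O)Nc2nnc(-c3cccs3)s2)cc1` gives 4750 nM, the only exact number available so far. Compound 2 `Cc1ccc(S(=O)(=O)Oc2cccc(/C=C(\C#N)C(=O)Nc3nnc(-c4cccs4)s3)c2)cc1` is reported only as a limit, > 20000 nM. Compound 3 `COc1ccc(S(=O)(=O)Oc2ccccc2/C=C(\C#N)C(=O)Nc2nnc(Cc3cccc(F)c3)s2)cc1` keeps the rest of compound 1 but carries 3-fluorobenzyl in place of thiophen-2-yl on an aromatic carbon. Among the measured compounds shown here, no measured pair isolates this change, so the estimate rests on compound 1 at 4750 nM, and the expected step of a 1.1-fold lower number from compound 1 to compound 3 (0.02 log units; within the scatter) is none beyond the scatter in this assay. For compound 3 the estimated value is 4500 nM, with an expected range of 1500 nM to 14000 nM.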

Compound 3, half-maximal inhibitory concentration: 1210 nM
Estimate against measurement, compound 3: 3.7-fold (0.57 log units) above; measured number below the stated range.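

In this assay, the carbon of the five-membered aromatic ring with 2 nitrogen and 1 sulfur proves open to change: 3-fluorobenzyl in place of thiophen-2-yl gives a 3.9-fold lower number from compound 1 to compound 3 (0.59 log units; beyond the scatter) as its step. This position therefore accepts the larger group, with its six-membered aromatic ring of carbon only, and the inhibition gains from it. Nothing shown here accounts for the gain.

From the compounds shown here alone, whether it comes from the fluorine, the methylene or the ring remains open. So does whether benzyl, phenyl or 2-phenylethyl would behave alike.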